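Fluoro to Methyl on a Weakly Inhibiting Pair

The source may report more compounds than this note shows. Statements on the series, on what has been measured and on what is new or still open speak of the compounds shown alone.

In a functional assay on OVCAR-4 cells (Homo sapiens) for inhibition (on this read-out lower numbers stand for stronger inhibition of growth and higher numbers for weaker inhibition of growth), compound 1 (`Nc1ccc(-c2nc3ccccc3s2)cc1C(F)(F)F`) gives 15800 nM and compound 2 (`Nc1ccc(-c2nc3ccccc3s2)cc1F`) gives 18600 nM. Among the compounds with values here, compound 2 holds the higher of only two numbers, yet the gap is a 1.2-fold higher number from compound 1 to compound 2 (0.07 log units; within the scatter), so the two cannot be told apart. Compound 3 (`Cc1cc(-c2nc3ccccc3s2)ccc1N`) carries methyl in place of fluoro on an aromatic carbon. Within the data shown here, one measured step bears on this change, the swap of trifluoromethyl for fluoro that links compound 1 to compound 2, and it stayed within the scatter. Among the measured compounds shown here, no measured compound carries methyl there, so that step is only a weak guide. No step beyond the scatter is expected in this assay, although the range is kept wide. The expected change is a 1.6-fold lower number from compound 2 to compound 3 (0.19 log units; within the scatter). Compound 3 is estimated at 12000 nM, with an expected range from 1500 nM to 30000 nM.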

Compound 3, concentration for 50% growth inhibition: 1100 nM
The estimate for compound 3 lay 11-fold (1.04 log units) above the measured number, outside the stated range (below it).
By their numbers in this assay, from the lowest: compound 3; then compounds 1 and 2 (each within the scatter of the next).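

In this assay, the group ortho to an amino group turns out to matter a great deal: methyl in place of fluoro brings a large drop in the number (a 17-fold lower number from compound 2 to compound 3 (1.23 log units; beyond the scatter)), and methyl in place of trifluoromethyl brings a similar one (a 14-fold lower number from compound 1 to compound 3 (1.16 log units; beyond the scatter)). The earlier step between fluoro and trifluoromethyl stayed within the scatter and gave no sign of this sensitivity, and among the three groups compared, only methyl stands apart. Nothing in the data shown accounts for the stronger inhibition of growth by compound 3.

The compounds shown leave open whether this gain belongs to methyl alone or extends to other groups at this place, such as ethyl, chlorine or methoxy. They also leave open whether a hydrogen there would fall with methyl or with fluoro and trifluoromethyl.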